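One oxygen added to a quiet series

A few compounds are considered here, and "the series" means these few. Any claim that something is new, unique, unknown or untested is made for them only; others in the source may bear on it.

The measured compounds:
compound 1, `Cn1c(-c2ccccc2)nc2c(Sc3ccccc3)ncnc21`, giving 1%
compound 2, `CSc1ccc(-c2nc3c(Sc4ccccc4)ncnc3n2C)cc1`, giving 0%
compound 3, `CSc1ccc(-c2nc3c(Sc4ccc(F)cc4)ncnc3n2C)cc1`, giving 7%

All three numbers come from an assay on isolated protein for inhibition of Ca2+/calmodulin-dependent protein kinase II (CaM kinase II) (Rattus norvegicus), tested at 30 uM; a higher number here means more inhibition at the concentration tested (going by the name of the read-out), a lower number less inhibition. Compound 2 has the lowest of the three numbers, but its nearest neighbour, compound 1, lies only a step away of a number 1 percentage points lower from compound 1 to compound 2 (within the scatter), and the furthest, compound 3, only a number 7 percentage points higher from compound 2 to compound 3 (within the scatter), so the three compounds cannot be told apart in this assay.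

Compound 4, `Cn1c(-c2ccc([S+](C)[O-])cc2)nc2c(Sc3ccccc3)ncnc21`, has not been measured. It differs from compound 2 in one place: a group of 3 heavy atoms (1 carbon, 1 oxygen, 1 sulfur; no ring) in place of a group of 2 heavy atoms (1 carbon, 1 sulfur; no ring), on an aromatic carbon. The group sits on an aromatic carbon of a six-membered aromatic ring of carbon only, para to a large group, which is the same position at which compound 2 differs from compound 1 by a methylsulfanyl group.

Within the data shown here, the steps that bear on the question are the two above. Adding methylsulfanyl at that position gave a number 1 percentage points lower from compound 1 to compound 2 (within the scatter), and adding fluoro elsewhere gave a number 7 percentage points higher from compound 2 to compound 3 (within the scatter); neither left the scatter. Among the measured compounds shown here, with no step in this assay larger than the scatter, the expectation for compound 4 is a step of a number 3 percentage points higher from compound 2 to compound 4 (within the scatter), that is, no change beyond the scatter. Compound 4 is therefore estimated at 3%, with a range from -5% to 12%.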

Compound 4, a percentage reported as inhibition, at one concentration (the size of the read-out at that concentration, not a potency): 8%
Compound 4: middle estimate off by 5 percentage points, on the low side, and the stated range covers the measured number.
By their numbers in this assay, from the lowest: compounds 2, 1, 3 and 4 (each within the scatter of the next).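

The group of 3 heavy atoms (one carbon, one oxygen, one sulfur) on the aromatic carbon para to a large group gives, in this assay, a number 8 percentage points higher from compound 2 to compound 4 (within the scatter) and so adds one oxygen to the methylsulfanyl group without a change that can be told from the scatter. Set against the hydrogen atom at the same place, the group gives a number 7 percentage points higher from compound 1 to compound 4 (within the scatter) in the same assay, and this step, like a number 1 percentage points lower from compound 1 to compound 2 (within the scatter), stays inside the scatter. This position has now carried two different sulfur-containing groups, and neither has separated from the hydrogen compound, so compounds 1, 2, 3 and 4 still cannot be told apart in this assay here.

Going by these compounds, whether an amine, a carboxylic acid or a longer chain on this aromatic carbon would move the number beyond the scatter stays open, and each number tells only the size of the effect at a single concentration. Nothing measured in these compounds speaks to why this change leaves the number within the scatter.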